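Changing the Sulfonyl Aryl Group: Expected Cytotoxicity

The compounds below may be only part of what the source reports. "The series", "measured", "known", "first", "only" and "open" are said of these compounds alone.

Compound 1, `O=S(=O)(Nc1ccc2oc(-c3ccccc3)nc2c1)c1cccc(C(F)(F)F)c1`: in an ADME assay on HEK293 cells (Homo sapiens) for cytotoxicity, read by resazurin assay, with a stated time of 48 h (on this read-out lower numbers stand for higher toxicity in this test and higher numbers for lower toxicity in this test), compound 1 reaches only a limit of the assay, not a number, > 100000 nM.
Compound 2, `O=S(=O)(Nc1ccc(-c2nc3ccccc3o2)cc1)c1cccc(Cl)c1`: in this assay compound 2 also reaches only a limit, > 100000 nM.
Compound 3, `COc1cccc(S(=O)(=O)Nc2ccc3oc(-c4ccccc4)nc3c2)c1`: in this assay compound 3 gives 63000 nM.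

Within the data shown here, compound 3 thus holds the only real number; the other two values are limits (the limit of > 100000 nM in this assay, at which 2 of the 3 values shown sit). Among the measured compounds shown here, the one measured step, an at least 1.5-fold lower number from compound 1 to compound 3 (0.20 log units; that floor lies within the scatter), sits on an aromatic carbon and lies within the scatter. Compound 4, `COc1ccc(Cl)cc1S(=O)(=O)Nc1ccc2oc(-c3ccccc3)nc2c1`, differs from compound 3 by 5-chloro-2-methoxyphenyl in place of 3-methoxyphenyl on a sulfonyl sulfur. For the measured compounds named here, no measured step touches the group on the sulfonyl sulfur, so the guide is thin. Compound 4 is estimated at 50000 nM, between 15000 nM and 150000 nM. That estimate means an expected step of a 1.3-fold lower number from compound 3 to compound 4 (0.10 log units; within the scatter), within the scatter.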

Compound 4, half-maximal cytotoxic concentration: 74000 nM
Estimate against measurement, compound 4: 1.5-fold (0.17 log units) below; low and high end bracket the measured number.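

Among these compounds, this is the first measured step at the group on the sulfonyl sulfur, and in this assay it reads a 1.2-fold higher number from compound 3 to compound 4 (0.07 log units; within the scatter). Replacing 3-methoxyphenyl with 5-chloro-2-methoxyphenyl, which adds one chlorine, therefore produces no change that can be told apart from ordinary repeat variation.

The compounds shown leave open whether a carboxylic acid or an amine on this ring, or a longer chain in place of the ring, would move the number on the sulfonyl sulfur. The room for comparison also stays narrow: the limit of > 100000 nM in this assay, at which 2 of the 4 values shown sit.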